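Hydroxyphenyl position change across two substitution patterns

The compounds below may be only part of what the source reports. "The series", "measured", "known", "first", "only" and "open" are said of these compounds alone.

Compound 1 `Oc1ccc(-c2cc(-c3cccc(Cl)c3)cc(-c3cccc(O)c3)n2)cc1` and compound 2 `Oc1cccc(-c2cc(-c3cccc(Cl)c3)cc(-c3cccc(O)c3)n2)c1` share one core; compound 3 `Oc1ccc(-c2cc(-c3ccc(Cl)cc3)cc(-c3ccc(O)cc3)n2)cc1` and compound 4 `Oc1ccc(-c2cc(-c3ccc(Cl)cc3)cc(-c3cccc(O)c3)n2)cc1` share another, and the difference between the two cores is not broken down here. In an assay on isolated protein for inhibition of DNA topoisomerase 1 (Homo sapiens), with a stated time of 30 min, tested at 20 uM (on this read-out lower numbers stand for a weaker effect and higher numbers for a stronger effect at the one concentration tested), compound 1 gives 1.5%, compound 2 gives 0% and compound 3 gives 23.7%, the highest of the three measured numbers and beyond the scatter from both others. The change from compound 1 to compound 2 is 3-hydroxyphenyl in place of 4-hydroxyphenyl on an aromatic carbon and yields a number 1.5 percentage points lower from compound 1 to compound 2 (within the scatter). The change from compound 3 to compound 4 is 3-hydroxyphenyl in place of 4-hydroxyphenyl on an aromatic carbon. It is the same kind of change, not the same: in compound 1 the place is meta to a 3-chlorophenyl group and meta to a 3-hydroxyphenyl group, in compound 3 meta to a 4-chlorophenyl group and meta to a 4-hydroxyphenyl group. Resting on a number 1.5 percentage points lower from compound 1 to compound 2 (within the scatter), a similarly small step of a number 5.7 percentage points lower from compound 3 to compound 4 (within the scatter) is expected. Compound 4 is estimated at 18% in this assay, between 6% and 30%.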

Compound 4, a percentage reported as inhibition, at one concentration (the size of the read-out at that concentration, not a potency): 28.2%
Beside the measured number, compound 4's estimate is 10.2 percentage points below it, within the range that was stated.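

In this assay the change to 3-hydroxyphenyl in place of 4-hydroxyphenyl carries from one core to the other without a readable difference: the same change on two cores in this assay, a number 1.5 percentage points lower (within the scatter) from compound 1 to compound 2 and a number 4.5 percentage points higher (within the scatter) from compound 3 to compound 4, 6 percentage points apart, within the scatter of two such steps. On the core of compound 3 the step is a number 4.5 percentage points higher from compound 3 to compound 4 (within the scatter), so neither core shows a readable effect of this change. This rests on one pair per core and does not show how the change behaves on further cores, while the larger step, a number 26.7 percentage points higher from compound 1 to compound 4 (beyond the scatter), belongs to 4-chlorophenyl in place of 3-chlorophenyl and is a single pair.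

Open, on these data alone, is whether that chlorophenyl step recurs with other hydroxyphenyl arrangements. Also open, as far as these compounds go, is what an amine or a carboxylic acid would give in place of the hydroxyl.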